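Cytotoxicity notes: from compound 2 to compound 4

This account rests on a few compounds, and the source may have more. Where it says the series, first, only, none or still open, it means among the compounds named here.

The series shares one core, shown by compound 1 `Cc1c(Cc2ccccc2)c(=O)oc2cc(OCC(O)CNc3ccccc3)ccc12`. In an ADME assay on A549 cells (Homo sapiens) for cytotoxicity, read by CellTiter-Glo (on this read-out lower numbers stand for higher toxicity in this test and higher numbers for lower toxicity in this test), compound 1 gives > 100000 nM, which is a limit of the assay and not a number. Compound 2 `Cc1c(Cc2ccccc2)c(=O)oc2cc(OCC(O)CNc3cc([N+](=O)[O-])ccc3O)ccc12` carries 2-hydroxy-5-nitrophenyl in place of phenyl on an amine nitrogen; in this assay compound 2 gives > 100000 nM, again a limit. Compound 3 `Cc1c(Cc2ccccc2)c(=O)oc2cc(OCC(O)CNc3nc4ccccc4[nH]3)ccc12` carries 1H-benzimidazol-2-yl on the amine nitrogen; in this assay compound 3 gives > 100000 nM, also a limit. All three values sit at the limit of > 100000 nM in this assay, at which 3 of the 3 values shown sit, so the steps a step that the two limits leave unreadable from compound 1 to compound 2, a step that the two limits leave unreadable from compound 1 to compound 3 and a step that the two limits leave unreadable from compound 2 to compound 3 cannot be sized.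

Compound 4 `Cc1ccc2nc(NCC(O)COc3ccc4c(C)c(Cc5ccccc5)c(=O)oc4c3)sc2c1` differs from compound 2 as follows: 6-methyl-1,3-benzothiazol-2-yl in place of 2-hydroxy-5-nitrophenyl on an amine nitrogen. Every measured exchange of the group on the amine nitrogen has so far left the value at the limit, and none is readable. No step beyond the scatter in this assay is therefore expected in either direction, and the step of a number no higher from compound 2 to compound 4 (the limit leaves the size open) is estimated as essentially none. Compound 4 is expected at 100000 nM, within 50000 nM to 300000 nM, most probably reported only as a limit.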

Compound 4, half-maximal cytotoxic concentration: > 100000 nM
Compound 4: no number, only a limit (the forecaster's own chance of this, stated with the estimate: 85%); the middle value sits exactly at the limit.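

In this assay compound 4 gives > 100000 nM, a limit and not a number, so none of its steps from compound 1, compound 2 or compound 3 can be read: the limit of > 100000 nM in this assay, at which 4 of the 4 values shown sit.

The compounds shown leave open whether any group on the amine nitrogen shifts the read-out in this assay, as none of them yields a number.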